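The compounds below may be only part of what the source reports. "The series", "measured", "known", "first", "only" and "open" are said of these compounds alone.

Compound 1 `O=C(O)c1ccc(NCc2cccc(Oc3ccccc3)c2)cc1` gives in a functional assay on CHO cells for agonist activity at Free fatty acid receptor 1 (Homo sapiens), read by a luciferase reporter (a higher number here means a larger maximal response, a lower number a smaller maximal response), a maximal response of 86%. Compound 2 `O=C(O)COc1ccc(NCc2cccc(Oc3ccccc3)c2)cc1`, which carries carboxymethoxy in place of carboxy on an aromatic carbon, gives 84% in this assay; the step is a number 2 percentage points lower from compound 1 to compound 2 (within the scatter). Within the data shown here, compound 2 thus stands at the lower of the two numbers so far, with compound 1 nearest to it and within the scatter.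

Compound 3 `CC(C)(Oc1ccc(NCc2cccc(Oc3ccccc3)c2)cc1)C(=O)O` differs from compound 2 by 1-carboxy-1-methylethyl in place of carboxymethyl on an oxygen on an aromatic ring. Among the measured compounds shown here, the one measured step that touches this part of the shared core is a number 2 percentage points lower from compound 1 to compound 2 (within the scatter), and it stayed within the scatter; there is no measured step for lengthening or branching the acid-bearing chain beyond carboxymethoxy. On this basis no step beyond the scatter is expected in this assay, i.e. a number 2 percentage points lower from compound 2 to compound 3 (within the scatter) as the estimated change. The maximal response of compound 3 is therefore estimated at 82%, with a range from 65% to 96%.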

Compound 3, largest response reached (reported as percent of maximum), in percent of the reference or control that the assay uses: 14%
Compound 3: middle estimate off by 68 percentage points, on the high side; measured number below the stated range.
By their numbers in this assay, from the lowest: compound 3; then compounds 2 and 1 (each within the scatter of the next).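

The oxygen on an aromatic ring tolerates one acid-bearing chain but not the other in this assay: 1-carboxy-1-methylethyl in place of carboxymethyl gives a number 70 percentage points lower from compound 2 to compound 3 (beyond the scatter), whereas the earlier change from carboxy to carboxymethoxy gave only a number 2 percentage points lower from compound 1 to compound 2 (within the scatter). Measured against the carboxy group, 1-carboxy-1-methylethoxy gives a number 72 percentage points lower from compound 1 to compound 3 (beyond the scatter), so a carboxylic acid on this chain does not by itself preserve the maximal response across these three compounds. No available evidence bears on the reason for this loss.

The compounds shown leave open whether 1-carboxyethyl, as an intermediate between carboxymethyl and 1-carboxy-1-methylethyl, would keep the response of compound 2 or share the loss seen with compound 3. They also leave open how a longer chain such as 2-carboxyethyl would behave at this oxygen.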